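This account rests on a few compounds, and the source may have more. Where it says the series, first, only, none or still open, it means among the compounds named here.

Among the compounds with values here, in an ADME assay on microsomes from liver (Mus musculus) for metabolic stability, read by mass spectrometry, with a stated time of 40 min, tested at 1 uM (on this read-out higher numbers stand for a more stable compound and lower numbers for a less stable compound), compound 1 `COc1cc(N2CCN(C(=O)C3CCC(O)CC3)CC2)ccc1Nc1nc(NC2CCCCC2)c2nc[nH]c2n1` gives 68% and holds the higher of the two numbers so far, while compound 2 `COc1cc(N2CCN(Cc3ccccn3)CC2)ccc1Nc1nc(NC2CCCCC2)c2nc[nH]c2n1` gives 38% on the same core. Compound 3 `COc1cc(N2CCN(CC3CCOC3)CC2)ccc1Nc1nc(NC2CCCCC2)c2nc[nH]c2n1` is still unmeasured and differs from compound 1 by one change ((oxolan-3-yl)methyl in place of (4-hydroxycyclohexyl)carbonyl on an amine nitrogen in a ring) on that same nitrogen. Within the data shown here, the only measured step there also removes the (4-hydroxycyclohexyl)carbonyl, and it is modest: a number 30 percentage points lower from compound 1 to compound 2 (beyond the scatter) when (pyridin-2-yl)methyl enters. From that single step, the expected change in this assay is a fall of similar direction but somewhat smaller size, estimated as a number 20 percentage points lower from compound 1 to compound 3 (beyond the scatter) for this pair. Compound 3 is thus estimated at 48% with an expected range from 28% to 68% in this measurement.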

Compound 3, percent of the compound remaining: 59%
The estimate for compound 3 lay 11 percentage points below the measured number, within the range that was stated.
By their numbers in this assay, from the lowest: compound 2; then compounds 3 and 1 (each within the scatter of the next).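

In this assay the result is a number 9 percentage points lower from compound 1 to compound 3 (within the scatter) and so (oxolan-3-yl)methyl can stand in for the (4-hydroxycyclohexyl)carbonyl on this ring nitrogen with no difference that stands clear of the scatter. The ring on the saturated chain carbon matters too, since oxolan-3-yl in place of pyridin-2-yl gives a number 21 percentage points higher from compound 2 to compound 3 (beyond the scatter) and losing the carbonyl alone therefore does not account for the fall seen with compound 2. Nothing measured here explains either step.

On these data alone, whether a plain methyl or a methoxyethyl group on this nitrogen would match compound 3 stays open. So does the part played by the hydroxyl, which a plain cyclohexylcarbonyl group would test.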